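The source may report more compounds than this note shows. Statements on the series, on what has been measured and on what is new or still open speak of the compounds shown alone.

Measured so far:
- compound 1, `COc1cc(NC(=O)Nc2cc(Nc3ccc(F)c(Cl)c3)ncn2)cc(OC)c1`: 53%
- compound 2, `COc1ccc(OC)c(Nc2cc(NC(=O)Nc3c(Cl)cccc3Cl)ncn2)c1`: 93.1%

Two compounds of the series have numbers in a functional assay on NCI-H1581 cells (Homo sapiens) for inhibition, read by MTT assay, with a stated time of 48 h, tested at 10 uM; a lower number here means less inhibition, a higher number more inhibition at the concentration tested (going by the name of the read-out). Compound 1 gives 53%, the lower of the two; compound 2 gives 93.1%, and the gap between them lies beyond the scatter. Among the compounds with values here, the two differ in more than one place, so no single step between them is worked out, and what the pair shows is only that compound 2 comes out higher.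

Compound 3, `COc1cc(NC(=O)Nc2cc(Nc3cc(C)cc(F)c3)ncn2)cc(OC)c1`, has not yet been measured in this assay . It differs from compound 1 in one place: 3-fluoro-5-methylphenyl in place of 3-chloro-4-fluorophenyl on a nitrogen on an aromatic ring. Within the data shown here, both groups entering and leaving are single aromatic rings of the same size with no donors or acceptors, and no measured pair isolates such an exchange, so there is nothing to set a direction from. The working expectation is a step of no size beyond the scatter, a number 5 percentage points lower from compound 1 to compound 3 (within the scatter), with a slight lean downward held only loosely. Compound 3 is therefore estimated at 48% in this assay , with a range from 25% to 70%.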

Compound 3, a percentage reported as inhibition, at one concentration (the size of the read-out at that concentration, not a potency): 28.3%
Beside the measured number, compound 3's estimate is 19.7 percentage points above it, and the stated range covers the measured number.
By their numbers in this assay, from the lowest: compound 3; then compound 1; then compound 2.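

Within the data shown here, the exchange of 3-chloro-4-fluorophenyl for 3-fluoro-5-methylphenyl gives the first single-place step in this assay: a number 24.7 percentage points lower from compound 1 to compound 3 (beyond the scatter). This position is therefore not indifferent to which substituted phenyl it carries, even though both groups have 8 heavy atoms, one six-membered aromatic ring of carbon only, and 0 hydrogen-bond donors or acceptors. Among these compounds, nothing at hand bears on why the number falls, and the single step does not separate the loss of chlorine from the gain of methyl or the different placing of fluorine.

Still open, as far as these compounds go, is how the position on the nitrogen would respond to a phenyl carrying an amine or a carboxylic acid, or to a phenyl carrying only a methyl or only a chlorine. Compound 2 differs from compound 1 and compound 3 in more than one place, so what share of its higher number belongs to this position remains unresolved.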